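Shortening the Chain of Compound 2

This account rests on a few compounds, and the source may have more. Where it says the series, first, only, none or still open, it means among the compounds named here.

Compound 2 `C/N=C(/NC#N)NCCCCCn1nc(-c2ccccc2)c(C)cc1=O` stands lowest of the three measured compounds in a functional assay on the whole organism with Rattus norvegicus as the target, at a dose of 100 mg/kg (a higher number here means more inhibition at the dose given (going by the name of the read-out), a lower number less inhibition), where compound 2 gives 28.5%. Compound 1 `C/N=C(/NC#N)NCCCCCn1nc(-c2ccccc2)ccc1=O` gives 47.6%, and compound 3 `CC/N=C(/NC#N)NCCCCn1nc(-c2ccccc2)cc(C)c1=O` gives 42.5%. Among the measured compounds shown here, the only measured step, a number 19.1 percentage points lower from compound 1 to compound 2 (beyond the scatter), concerns a methyl on an aromatic carbon and not the chain. Compound 4 `C/N=C(/NC#N)NCCCCn1nc(-c2ccccc2)c(C)cc1=O` differs from compound 2 by a group of 7 heavy atoms (3 carbon, 4 nitrogen; no ring) in place of a group of 8 heavy atoms (4 carbon, 4 nitrogen; no ring), on a saturated chain carbon, four bonds along the chain from an aromatic nitrogen. For the measured compounds named here, no measured step bears directly on this change; compound 3 carries the shorter chain, but it also differs from compound 2 in two other places, so its value shows only that the shorter chain still inhibits in this assay. Compound 4 is therefore expected to give 33%, with a likely range from 15% to 55%. The expected step, a number 4.5 percentage points higher from compound 2 to compound 4 (within the scatter), is estimated to stay within the scatter.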

Compound 4, a percentage reported as inhibition, in the whole organism at one dose (the size of the read-out at that dose, not a potency): 46.4%
Compound 4: the middle estimate sits 13.4 percentage points below what was measured; the range from low to high includes it.
By their numbers in this assay, from the lowest: compound 2; then compounds 3, 4 and 1 (each within the scatter of the next).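

In this assay, the change on a saturated chain carbon, four bonds along the chain from an aromatic nitrogen, can now be read on its own: it gives a number 17.9 percentage points higher from compound 2 to compound 4 (beyond the scatter). This position therefore matters in this assay, even with the methyl on the aromatic carbon kept in place. Nothing measured here explains the step. As far as these compounds go, it remains open whether a longer chain, or an amine at this position, would shift the number further, and whether the same change would give a similar step without the methyl.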